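A few compounds are considered here, and "the series" means these few. Any claim that something is new, unique, unknown or untested is made for them only; others in the source may bear on it.

Series notes. Compound 1 `NS(=O)(=O)c1ccc(SCCO)c([N+](=O)[O-])c1` and compound 3 `NS(=O)(=O)c1ccc(SCCO)c(C(=O)O)c1` share one core; compound 2 `NS(=O)(=O)c1ccc(S(=O)(=O)CCCO)c([N+](=O)[O-])c1` and the unmeasured compound 4 `NS(=O)(=O)c1ccc(S(=O)(=O)CCCO)c(C(=O)O)c1` share another. How the two cores differ is not broken down here.

In a physicochemical assay for acid dissociation, compound 1 gives 9.42, compound 3 gives 10.5, and compound 2 gives 8, the lowest of the three measured numbers.

Between compound 1 and compound 3 the change is carboxy in place of nitro on an aromatic carbon, and the step is a number 1.08 log units higher from compound 1 to compound 3 (beyond the scatter).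

Between compound 2 and compound 4 the change is carboxy in place of nitro on an aromatic carbon. This is the same kind of change as from compound 1 to compound 3, not the same change: there the group sits ortho to a (2-hydroxyethyl)sulfanyl group, here it sits ortho to a group of 7 heavy atoms, while the meta relation to a sulfamoyl group is common to both.

Within the data shown here, the step expected from compound 2 to compound 4 in this assay is a number 1.10 log units higher from compound 2 to compound 4 (beyond the scatter), set beside the earlier one because the measured step of a number 1.08 log units higher from compound 1 to compound 3 (beyond the scatter) is the only guide available and the change is of the same kind. Compound 4 is therefore estimated at 9.1, with a range from 8.5 to 9.7.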

Compound 4, acid dissociation constant: 9.28
The estimate for compound 4 lay 0.18 log units below the measured number, and the stated range covers the measured number.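

In this assay, carboxy in place of nitro on an aromatic carbon gives a step on the core of compound 2 (a number 1.28 log units higher from compound 2 to compound 4 (beyond the scatter)) that runs the same way as the step on the core of compound 1 (a number 1.08 log units higher from compound 1 to compound 3 (beyond the scatter)), and both steps are large and beyond the scatter. Among these compounds, this shows that the direction of the change carried over between these two cores, but it rests on only two pairs and does not show that the step would hold on any further core. Nothing at hand accounts for the step on either core.

Left open is how an amine or a nitrile on the same aromatic carbon would compare with nitro and carboxy in this assay. Also open, on these data alone, is whether the step persists when a longer chain stands in place of the group of 7 heavy atoms.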